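Bcl-2 displacement series: notes toward compound 4

This account rests on a few compounds, and the source may have more. Where it says the series, first, only, none or still open, it means among the compounds named here.

Measured in an assay on isolated protein for displacement of a labelled ligand from Apoptosis regulator Bcl-2 (Homo sapiens), with a stated time of 15 min; on this read-out lower numbers stand for stronger inhibition and higher numbers for weaker inhibition:
compound 1 `CC1(C)CCC(CN2CCN(c3ccc(C(=O)NS(=O)(=O)c4ccc(NCC5CCOCC5)c([N+](=O)[O-])c4)c(Oc4cnc5[nH]ccc5c4)c3)CC2)=C(c2ccc(Cl)cc2C(F)(F)F)C1` gives 0.86 nM
compound 2 `COc1ccc(C2=C(CN3CCN(c4ccc(C(=O)NS(=O)(=O)c5ccc(NCC6CCOCC6)c([N+](=O)[O-])c5)c(Oc5cnc6[nH]ccc6c5)c4)CC3)CCC(C)(C)C2)cc1` gives 3.8 nM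
compound 3 `CN1CCC(CNc2ccc(S(=O)(=O)NC(=O)c3ccc(N4CCN(CC5=C(c6ccc(C(F)(F)F)cc6)CC(C)(C)CC5)CC4)cc3Oc3cnc4[nH]ccc4c3)cc2[N+](=O)[O-])C1` gives 2.4 nM

Compound 3 stands second highest of the three numbers. Its nearest neighbour is compound 2, within the scatter; compound 1 lies lower, beyond the scatter.

Compound 4 `CC1(C)CCC(CN2CCN(c3ccc(C(=O)NS(=O)(=O)c4ccc(OCC5CCOC5)c([N+](=O)[O-])c4)c(Oc4cnc5[nH]ccc5c4)c3)CC2)=C(c2ccc(C(F)(F)F)cc2)C1` is not yet measured. It differs from compound 3 in one place: (oxolan-3-yl)methoxy in place of ((1-methylpyrrolidin-3-yl)methyl)amino on an aromatic carbon, on an aromatic carbon of a six-membered aromatic ring of carbon only, ortho to a nitro group and para to a large group.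

Going by the values given here, the only measured single-place step is a 4.4-fold higher number from compound 1 to compound 2 (0.65 log units; beyond the scatter), which changes the aryl group on a double-bonded ring carbon, not the position altered here. Among the compounds with values here, no measured pair changes the group that leaves in compound 4, so nothing bears directly on this step. The three measured values together span a modest range, and a step of similar modest size, or none beyond the scatter, is expected in this assay.

Compound 4 is estimated at 5 nM, range 1.5 nM to 20 nM, which means an expected step of a 2.1-fold higher number from compound 3 to compound 4 (0.32 log units; beyond the scatter).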

Compound 4, half-maximal inhibitory concentration: 4.4 nM
Estimate against measurement, compound 4: 1.1-fold (0.06 log units) above, and the stated range covers the measured number.
By their numbers in this assay, from the lowest: compound 1; then compounds 3, 2 and 4 (each within the scatter of the next).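

In this assay, going by these compounds alone, a 1.8-fold higher number from compound 3 to compound 4 (0.26 log units; within the scatter) is the first single-place step read at this position, on an aromatic carbon ortho to a nitro group and para to a large group. (Oxolan-3-yl)methoxy and ((1-methylpyrrolidin-3-yl)methyl)amino cannot be told apart here, although the leaving group counts 1 hydrogen-bond donor and the entering group 0, so this position accepts the exchange without a change beyond the scatter. No measurement in hand accounts for this result.

The step alters the linking atom and the ring hetero atom together, and a (1-methylpyrrolidin-3-yl)methoxy group would separate the two. Going by these compounds, how a carboxylic acid or a longer chain at this position would read remains open.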